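The compounds below may be only part of what the source reports. "The series", "measured", "known", "first", "only" and "open" are said of these compounds alone.

Compound 1 `ClCc1ccc(Cn2cnc3c(Cl)ncnc32)cc1` gives 2450 nM in a functional assay on EKVX cells (Homo sapiens) for cytotoxicity, read by sulforhodamine B assay, with a stated time of 48 h; a lower number here means a stronger inhibitor of growth, a higher number a weaker inhibitor of growth.
Compound 2 `ClCc1ccccc1Cn1cnc2c(Cl)nc(Cl)nc21` gives 1770 nM in this assay.

Among the measured compounds shown here, compound 2 has the lowest of the two numbers measured so far, but its nearest neighbour, compound 1, sits within the scatter of it, so neither compound can be called the stronger inhibitor of growth on this evidence. Compound 3 `ClCc1ccccc1Cn1cnc2c(Cl)ncnc21` has not yet been measured in this assay. It differs from compound 2 in one place: hydrogen in place of chloro on an aromatic carbon, with the rest of the structure left untouched. For the measured compounds named here, no pair of measured compounds shows what the loss of this chloro group from the shared core does here, so there is no measured step to lean on. The two numbers in hand lie close together, and the removal of the chloro group is not expected to move the value beyond the scatter in either direction. Compound 3 is therefore estimated at 2500 nM, within a range of 1000 nM to 7000 nM. The step this estimate means, a 1.4-fold higher number from compound 2 to compound 3 (0.15 log units; within the scatter), is expected to stay within the scatter.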

Compound 3, concentration for 50% growth inhibition: 3090 nM
Compound 3: the middle estimate sits 1.2-fold (0.09 log units) below what was measured; the range from low to high includes it.
By their numbers in this assay, from the lowest: compounds 2, 1 and 3 (each within the scatter of the next).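

Among the compounds shown here, this pair is the first to isolate the chloro group on the aromatic carbon between two ring nitrogen atoms, and in this assay its exchange for hydrogen gives a 1.7-fold higher number from compound 2 to compound 3 (0.24 log units; within the scatter). The step lies within the scatter, so compound 2 and compound 3 cannot be told apart, and this position shows no measurable dependence on the chloro group in this pair. Growth inhibition in this range therefore does not require the chloro group at this position, although this rests on a single exchange on a single core. Nothing available on these compounds bears on the reason for this result.

The compounds shown leave open whether a different group at this position, such as an amine, a methoxy group or a longer chain, would move the value beyond the scatter. They also leave open what happens when the chloro group that stays in compound 3, meta to this position, gives way to an amine or to hydrogen.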